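Ester swap on the core of compound 1

The source may hold more compounds than are shown below. What is called first, only, known or untested is meant among the compounds shown, and "the series" means these compounds.

Compound 1 `CC(C)C(=O)Oc1cc(O)c2c(c1)OC(c1ccc(O)cc1)CC2=O`: 15900 nM
Compound 2 `CCOC(=O)N/N=C1\CC(c2ccc(O)cc2)Oc2cc(O)cc(O)c21`: 4350 nM

Of the compounds shown here, two have been measured in a functional assay on HCT-116 cells (Homo sapiens) for cytotoxicity, read by crystal violet staining and colony formation, with a stated time of 7 days (a higher number here means a weaker inhibitor, a lower number a stronger inhibitor), so far. Compound 1 stands at the highest of the two numbers, and its nearest neighbour is compound 2, whose value lies clearly lower, with a gap beyond the scatter. The two differ in more than one place, so only their two values can be compared.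

Compound 3 `Cc1ccccc1C(=O)Oc1cc(O)c2c(c1)OC(c1ccc(O)cc1)CC2=O` follows from compound 1 by a single change: 2-methylphenyl in place of isopropyl on a carbonyl carbon. Among the measured compounds shown here, no measured pair shows this change, so its effect is not known from the data. Given the value of compound 1 at 15900 nM and no step to lean on, a step of at most modest size, in either direction and possibly none beyond the scatter, is expected from compound 1 to compound 3, as a 1.3-fold lower number from compound 1 to compound 3 (0.12 log units; within the scatter). Compound 3 is therefore estimated at 12000 nM, with a range from 4000 nM to 40000 nM.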

Compound 3, half-maximal inhibitory concentration: 6030 nM
The estimate for compound 3 lay 2.0-fold (0.30 log units) above the measured number; the range from low to high includes it.
By their numbers in this assay, from the lowest: compounds 2 and 3 (each within the scatter of the next); then compound 1.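

In this assay, among the compounds shown here, putting 2-methylphenyl in place of isopropyl on a carbonyl carbon gives a 2.6-fold lower number from compound 1 to compound 3 (0.42 log units; beyond the scatter) and so provides the first step that can be read at this position. It shows that the group on this carbonyl carbon can shift the number beyond the scatter, here with a larger group carrying one six-membered aromatic ring of carbon only, while the count of hydrogen-bond donors and acceptors stays at zero on both sides. Nothing at hand bears on why the number moves with this change.

The compounds shown do not separate the part of the ring from that of its methyl group, which a plain phenyl group on the same carbonyl carbon would address. As far as these compounds go, how an amine or a carboxylic acid at this position would read also remains open.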